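The source may report more compounds than this note shows. Statements on the series, on what has been measured and on what is new or still open speak of the compounds shown alone.

Working notes on the series. Among the measured compounds shown here, compound 3 `Nc1nccc2c1ncn2[C@H]1C[C@H](O)[C@@H](CO)O1` is the only member with a number in a functional assay on the whole organism (Pleural cavity) with Rattus norvegicus as the target; a lower number here means that less compound is needed, a higher number that more compound is needed for the effect: compound 3 gives 10 mg/kg. Compound 1 `Clc1[nH]ccc2ncnc1-2` gives in this assay a value of > 9 mg/kg, which is a limit of the assay and not a number. Compound 2 `OC[C@H]1OC(n2cnc3c(Nc4ccccc4)nccc32)[C@H](O)[C@@H]1O` likewise reaches in this assay only a limit of the assay, reported as > 9 mg/kg. For the measured compounds named here, no step between two measured compounds that differ in a single place is available, so compound 3 stands on its own number, with the two limits beside it and nothing to rank it against.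

Compound 4 `OC[C@H]1O[C@@H](n2cnc3cnccc32)C[C@@H]1O` is not yet measured. It differs from compound 3 in one place: hydrogen in place of amino on an aromatic carbon. The step of a 1.5-fold higher number from compound 3 to compound 4 (0.18 log units; within the scatter) is expected to be modest, toward more compound needed, and possibly not beyond the scatter of the measurement. A limit rather than a number is a real possibility for compound 4 because the limit of > 9 mg/kg in this assay, at which 2 of the 3 values shown sit, shows where most of the series sits. Compound 4 is therefore expected at 15 mg/kg, within a range from 6 mg/kg to 40 mg/kg.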

Compound 4, dose for half-maximal effect: > 9 mg/kg
Compound 4: a limit, no number; the forecaster's own chance of this, stated with the estimate: 50%; the middle value does not contradict the limit.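

Compound 4 gives > 9 mg/kg in this assay, which is a limit of the assay and not a number. The step between compound 3 and compound 4 therefore cannot be read. The compounds shown leave open whether hydrogen in place of amino on an aromatic carbon changes the dose needed.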